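Sulfur-linked isopentyl chain at the ether position

A few compounds are considered here, and "the series" means these few. Any claim that something is new, unique, unknown or untested is made for them only; others in the source may bear on it.

Three compounds with a shared core carry different groups on the oxygen attached to the aromatic ring bearing trifluoromethyl. Compound 1 `CC(C)COc1cc(C(F)(F)F)ccc1CNC(=O)C(C)c1ccc(NS(C)(=O)=O)c(F)c1` gives 0.8 nM in an assay on CHO cells for antagonist activity at transient receptor potential cation channel subfamily V member 1 (Homo sapiens), read by FLIPR; on this read-out lower numbers stand for stronger inhibition and higher numbers for weaker inhibition. Compound 2 `CC(C(=O)NCc1ccc(C(F)(F)F)cc1OC1CCCC1)c1ccc(NS(C)(=O)=O)c(F)c1` gives 0.6 nM in this assay. Compound 3 `CC(C(=O)NCc1ccc(C(F)(F)F)cc1OCc1ccc(F)cc1)c1ccc(NS(C)(=O)=O)c(F)c1` gives 0.5 nM in this assay, the lowest of the three numbers, though the separation from its neighbours is small: a 1.6-fold lower number from compound 1 to compound 3 (0.20 log units; within the scatter) and a 1.2-fold lower number from compound 2 to compound 3 (0.08 log units; within the scatter), both within the scatter. Exchanging alkyl for cycloalkyl on the oxygen likewise moved little, a 1.3-fold lower number from compound 1 to compound 2 (0.12 log units; within the scatter).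

Compound 4 `CC(C)CCSc1cc(C(F)(F)F)ccc1CNC(=O)C(C)c1ccc(NS(C)(=O)=O)c(F)c1` is not yet measured. The change from compound 3 is isopentylsulfanyl in place of (4-fluorobenzyl)oxy on an aromatic carbon; it is placed on an aromatic carbon of a six-membered aromatic ring of carbon only, ortho to a large group and meta to a trifluoromethyl group. Among the measured compounds shown here, of the measured steps, the one from compound 1 to compound 3 is the closest analogue, since it also swaps a branched alkyl for the (4-fluorobenzyl) group, and it stayed within the scatter. For the measured compounds named here, no measured step covers sulfur in place of oxygen at this position, so the range for compound 4 is kept wide. Compound 4 is expected to give about 1.5 nM in this assay, within 0.5 nM to 5 nM, an estimated step of a 3.0-fold higher number from compound 3 to compound 4 (0.48 log units; beyond the scatter) that may not exceed the scatter.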

Compound 4, inhibition constant: 1.4 nM
For compound 4 the middle estimate is 1.1-fold (0.03 log units) above the measured one; measured number inside the range.
By their numbers in this assay, from the lowest: compounds 3, 2, 1 and 4 (each within the scatter of the next, the first and the last beyond it).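

Up to this point the three groups on oxygen had moved the number only within the scatter, whereas isopentylsulfanyl gives the first changes at this aromatic carbon that pass it: in this assay there is a 2.8-fold higher number from compound 3 to compound 4 (0.45 log units; beyond the scatter) and a 2.3-fold higher number from compound 2 to compound 4 (0.37 log units; beyond the scatter) in the two steps that replace a ring-bearing group. Against the acyclic isobutoxy of compound 1 the result is different, with a 1.8-fold higher number from compound 1 to compound 4 (0.24 log units; within the scatter) leaving compound 4 and compound 1 not separated, so the new group is distinguishable from only two of the three ether compounds and the steps stay modest. The compounds shown offer no measurement that explains these steps.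

Each step changes the linking atom and the attached group together, so the contribution of sulfur in place of oxygen remains unresolved; an isopentyloxy group on the same aromatic carbon would separate the two. Also open, from the compounds shown here alone, is how the number responds to an isopentylamino group or to a longer chain on sulfur at this position.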